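The source may hold more compounds than are shown below. What is called first, only, known or untested is meant among the compounds shown, and "the series" means these compounds.

Working notes on a small set of anilide amides bearing a tertiary alcohol, all assessed in a functional assay on DU-145 cells (Homo sapiens) for antiproliferative activity, read by fluorescence and propidium iodide staining, with a stated time of 96 h; on this read-out lower numbers stand for stronger inhibition and higher numbers for weaker inhibition.

Compound 1 `CC(O)(CSc1cccc(C(F)(F)F)c1)C(=O)Nc1cc(C(F)(F)F)cc(C(F)(F)F)c1` gives 10000 nM in this assay. Compound 2 `CC(O)(CSc1ccccc1C(F)(F)F)C(=O)Nc1cc(C(F)(F)F)cc(C(F)(F)F)c1` differs from compound 1 by 2-(trifluoromethyl)phenyl in place of 3-(trifluoromethyl)phenyl on a sulfur; in this assay compound 2 gives 8660 nM, and the step of a 1.2-fold lower number from compound 1 to compound 2 (0.06 log units; within the scatter) is within the scatter, so no direction of change can be read from this pair.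

Compound 3 `CC(O)(CS(=O)(=O)c1cccc(C(F)(F)F)c1)C(=O)Nc1cc(C(F)(F)F)cc(C(F)(F)F)c1` carries the sulfonyl in place of the sulfide of compound 1; the difference between the two cores is not broken down here. In this assay compound 3 gives 11500 nM, which sits within the scatter of both compound 1 and compound 2, so the three measured compounds cannot be ordered.

Compound 4 `CC(O)(CS(=O)(=O)c1ccccc1C(F)(F)F)C(=O)Nc1cc(C(F)(F)F)cc(C(F)(F)F)c1` has not yet been measured. It is related to compound 3 by 2-(trifluoromethyl)phenyl in place of 3-(trifluoromethyl)phenyl on a sulfonyl sulfur. This is the same kind of change as that from compound 1 to compound 2, though not the same: there the change sat on a sulfur, here it sits on a sulfonyl sulfur. Since the earlier step of a 1.2-fold lower number from compound 1 to compound 2 (0.06 log units; within the scatter) was within the scatter, the expectation for compound 4 is a step of similar size, a 1.2-fold lower number from compound 3 to compound 4 (0.06 log units; within the scatter), also within the scatter. Compound 4 is therefore estimated at 10000 nM in this assay, with a plausible range from 5500 nM to 20000 nM. A measurement of compound 4 in this assay will show whether this holds.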

Compound 4, half-maximal inhibitory concentration: 11000 nM
Beside the measured number, compound 4's estimate is 1.1-fold (0.04 log units) below it, and the stated range covers the measured number.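

Setting 2-(trifluoromethyl)phenyl in place of 3-(trifluoromethyl)phenyl on a sulfonyl sulfur gives a 1.0-fold lower number from compound 3 to compound 4 (0.02 log units; within the scatter) in this assay, so no direction of change can be read from this pair. Set beside the same change on the core of compound 1, the two steps show no difference: the same change on two cores in this assay, a 1.2-fold lower number (0.06 log units; within the scatter) from compound 1 to compound 2 and a 1.0-fold lower number (0.02 log units; within the scatter) from compound 3 to compound 4, 1.1-fold (0.04 log units) apart, within the scatter of two such steps What carries over between the two cores is therefore only the absence of a readable effect: in both pairs this change leaves the number within the scatter, but this does not show that the change would act alike on a core where it had a readable effect, nor does it say anything about cores beyond these two.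

The compounds shown leave open whether any change on this aryl group can move the number beyond the scatter, since the only variation here is between 2-(trifluoromethyl)phenyl and 3-(trifluoromethyl)phenyl. Also open, from the compounds shown here alone, is what would follow from a nitrile, an amine or a carboxylic acid in place of the trifluoromethyl on that ring, or from a longer chain in place of the saturated chain carbon on the sulfur.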